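Nitro in place of chloro: working notes on the series

The compounds below may be only part of what the source reports. "The series", "measured", "known", "first", "only" and "open" are said of these compounds alone.

Measured so far:
compound 1 `CC1=CC[C@H](C(C)(C)NC(=S)N/N=C/c2ccccc2)CC1`, 71400 nM
compound 2 `CC1=CC[C@H](C(C)(C)NC(=S)N/N=C/c2ccccc2O)CC1`, 10600 nM
compound 3 `CC1=CC[C@H](C(C)(C)NC(=S)N/N=C/c2cccc(Cl)c2)CC1`, 35800 nM

In a functional assay on U-251 cells (Homo sapiens) for inhibition, read by sulforhodamine B assay, with a stated time of 48 h (a lower number here means a stronger inhibitor of growth, a higher number a weaker inhibitor of growth), compound 3 stands second highest of the three numbers, with compound 1 nearest (a 2.0-fold lower number from compound 1 to compound 3 (0.30 log units; within the scatter), within the scatter) and compound 2 furthest (a 3.4-fold higher number from compound 2 to compound 3 (0.53 log units; beyond the scatter)). Compound 4 `CC1=CC[C@H](C(C)(C)NC(=S)N/N=C/c2cccc([N+](=O)[O-])c2)CC1` differs from compound 3 by nitro in place of chloro on an aromatic carbon. Among the measured compounds shown here, no measured step exchanges one substituent for another on this aromatic carbon; the only guides are the substitutions onto the bare ring, a 6.7-fold lower number from compound 1 to compound 2 (0.83 log units; beyond the scatter) and a 2.0-fold lower number from compound 1 to compound 3 (0.30 log units; within the scatter), one modest and one within the scatter. Neither bears directly on a nitro group, so in this assay no step beyond the scatter is expected in either direction. For compound 4 the estimate is 30000 nM (range 10000 nM to 90000 nM), an expected step of a 1.2-fold lower number from compound 3 to compound 4 (0.08 log units; within the scatter).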

Compound 4, concentration for total growth inhibition: > 100000 nM
Compound 4: no number, only a limit (the forecaster's own chance of this, stated with the estimate: 10%); at least 3.3-fold (0.52 log units) between middle value and limit.
By their numbers in this assay, from the lowest: compound 2; then compounds 3 and 1 (each within the scatter of the next). At a limit, above all of these: compound 4.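

Compound 4 gives no number, only a limit of the assay: the limit of > 100000 nM in this assay, at which 1 of the 4 values shown sits. Even so, in this assay the exchange of one substituent for another on this aromatic carbon now has a reading, an at least 2.7-fold higher number from compound 3 to compound 4 (0.44 log units; beyond the scatter), so nitro and chloro are not interchangeable here. Against the bare ring the reading is looser, an at least 1.4-fold higher number from compound 1 to compound 4 (0.14 log units; that floor lies within the scatter), so nitro in place of hydrogen is not shown to move the number beyond the scatter.

On these data alone, how far the true value lies past the limit stays open, as does where an amine or a carboxylic acid on this aromatic carbon would fall.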